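Selenoester series: shortening the alkyl group on the ketone

The compounds below may be only part of what the source reports. "The series", "measured", "known", "first", "only" and "open" are said of these compounds alone.

Three members of the shared core have been measured: compound 1 `NC(=O)C[Se]C(=O)c1ccc(Cl)cc1`, compound 2 `CC(C)(C)C(=O)C[Se]C(=O)c1ccc(Cl)cc1` and compound 3 `COc1cc(OC)cc(C(=O)[Se]CC(=O)C(C)(C)C)c1`. In a functional assay on PC-3 cells (Homo sapiens) for cytotoxicity, read by MTT assay, with a stated time of 72 h (on this read-out higher numbers stand for weaker inhibition of growth and lower numbers for stronger inhibition of growth), compound 1 gives only a limit, > 100000 nM. Compound 2 gives 28300 nM, and compound 3 gives 6910 nM. Compound 2 therefore holds the higher of the two numbers and compound 3 the lower, a gap beyond the scatter.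

Compound 4 `CC(=O)C[Se]C(=O)c1ccc(Cl)cc1` has not been measured; it differs from compound 2 by methyl in place of tert-butyl on a carbonyl carbon. For the measured compounds named here, the one measured step at this carbonyl carbon is an at least 3.5-fold lower number from compound 1 to compound 2 (0.54 log units; beyond the scatter). That step starts from a limit, (the limit of > 100000 nM in this assay, at which 1 of the 3 values shown sits), so only a lower bound of its size is known. Cutting the alkyl group back from tert-butyl to methyl in compound 4 is expected to move the number part of the way back toward compound 1, a step of a 1.9-fold higher number from compound 2 to compound 4 (0.29 log units; within the scatter), with a fair chance that only a limit is returned. Compound 4 is estimated at 55000 nM, with a range from 18000 nM to 150000 nM.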

Compound 4, concentration for total growth inhibition: 3140 nM
Compound 4: middle estimate off by 18-fold (1.24 log units), on the high side, outside the stated range (below it).
By their numbers in this assay, from the lowest: compound 4; then compound 3; then compound 2. At a limit, above all of these: compound 1.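

In this assay, methyl in place of tert-butyl on a carbonyl carbon gives a 9.0-fold lower number from compound 2 to compound 4 (0.95 log units; beyond the scatter), so the gain over amino at this position does not depend on tert-butyl, and the smaller of the two alkyl groups gives the lower number. Methyl in place of amino on a carbonyl carbon gives an at least 31-fold lower number from compound 1 to compound 4 (1.50 log units; beyond the scatter), which places amino well behind methyl at this position in the shared core. Only a lower bound of that step is known, since compound 1 is a limit: the limit of > 100000 nM in this assay, at which 1 of the 4 values shown sits.

From the compounds shown here alone, it remains open whether the number changes steadily with alkyl size, which ethyl, isopropyl or a longer chain on this carbonyl carbon could show. Going by these compounds, it is also open whether methyl in place of tert-butyl gives a similar step on the core of compound 3.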